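Swapping a benzylamino arm for an arylthio arm

The source may report more compounds than this note shows. Statements on the series, on what has been measured and on what is new or still open speak of the compounds shown alone.

Among the measured compounds shown here, compound 2 `Nc1cc(N)c2nc(-c3ccccc3)c(NCc3ccc(F)cc3)nc2c1` holds the lower of the two numbers so far: in a functional assay on OVCAR-8 cells (Homo sapiens) for inhibition, read by sulforhodamine B assay, with a stated time of 48 h (on this read-out higher numbers stand for weaker inhibition of growth and lower numbers for stronger inhibition of growth), compound 2 gives 6030 nM, while compound 1 `COc1ccc(CNc2nc3cc(N)cc(N)c3nc2-c2ccccc2)cc1OC` gives 33900 nM. For the measured compounds named here, the one measured step, a 5.6-fold lower number from compound 1 to compound 2 (0.75 log units; beyond the scatter), changed only the aryl group on the benzyl chain. Compound 3 `Nc1cc(N)c2nc(-c3ccccc3)c(Sc3ccc(Cl)c(Cl)c3)nc2c1` differs from compound 2 by (3,4-dichlorophenyl)sulfanyl in place of (4-fluorobenzyl)amino on an aromatic carbon. Going by the values given here, no measured step covers the exchange of the linking atoms, so that step speaks to it only loosely, and a step within or just beyond the scatter, in either direction, is expected. Compound 3 is therefore estimated at 8000 nM (range 2000 nM to 32000 nM). That is an expected step of a 1.3-fold higher number from compound 2 to compound 3 (0.12 log units; within the scatter).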

Compound 3, concentration for total growth inhibition: < 100000 nM
Compound 3 gave a limit, no number; the forecaster's own chance of this, stated with the estimate: 10%; the middle value does not contradict the limit.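

Compound 3 gave only a limit (< 100000 nM) and no number, so the step from compound 2 to compound 3 cannot be read. From the compounds shown here alone, whether (3,4-dichlorophenyl)sulfanyl gives stronger or weaker inhibition of growth than (4-fluorobenzyl)amino remains open.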